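The source may report more compounds than this note shows. Statements on the series, on what has been measured and on what is new or still open speak of the compounds shown alone.

Two compounds carry numbers in a functional assay on the whole organism (strain NMRI) with Mus musculus as the target, with a stated time of 4 h; a lower number here means that less compound is needed, a higher number that more compound is needed for the effect. Compound 1 `Cc1ccc(-c2nc3ccc(Br)cn3c2/C=N/O)cc1` gives 20 mg/kg. Compound 2 `Cc1cccn2c(/C=N/OCc3cn(Cc4ccc([N+](=O)[O-])cc4)nn3)c(-c3ccc(F)cc3)nc12` gives 40 mg/kg, the higher of the two numbers, though its gap to compound 1 lies within the scatter. Compound 3 `Cc1ccc(Cn2cc(CO/N=C/c3c(-c4ccc(F)cc4)nc4c(C)cccn34)nn2)cc1` is not yet measured; it differs from compound 2 by methyl in place of nitro on an aromatic carbon, that is, 4-nitrobenzyl becoming 4-methylbenzyl. For the measured compounds named here, no step between measured compounds covers such a change, so the expected step from compound 2 to compound 3 is no change at the digits printed from compound 2 to compound 3 (within the scatter), not beyond the scatter in either direction. Compound 3 is therefore estimated at 40 mg/kg, with a range from 15 mg/kg to 100 mg/kg.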

Compound 3, minimum effective dose: 40 mg/kg
The estimate for compound 3 equals the measured number at the digits printed; low and high end bracket the measured number.
By their numbers in this assay, from the lowest: compounds 1, 2 and 3 (each within the scatter of the next).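

In this assay, 4-nitrobenzyl becoming 4-methylbenzyl gives no change at the digits printed from compound 2 to compound 3 (within the scatter), the first step read at this position. Nitro and methyl on this aromatic carbon are therefore not separated by this read-out, although they differ in size and in hydrogen-bond acceptors. Nothing measured on the compounds gives a reason for this flat step. Going by these compounds, whether an amine or a carboxylic acid on the same aromatic carbon would move the dose remains open. So does whether the step holds with the core of compound 1, as this single pair speaks only for the core of compound 2.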